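From isopropyl to 4-hydroxycyclohexyl on a shared core

A few compounds are considered here, and "the series" means these few. Any claim that something is new, unique, unknown or untested is made for them only; others in the source may bear on it.

Measured so far in a functional assay on LNCaP cells (Homo sapiens) for cytotoxicity; on this read-out lower numbers stand for stronger inhibition and higher numbers for weaker inhibition:
compound 1 `CNC(=O)Nc1ccc(-c2nc(N3CC4CCC(C3)O4)c3cnn(C(C)C)c3n2)cc1` gives 5 nM as its value
compound 2 `O=C(Nc1ccc(-c2nc(N3CC4CCC(C3)O4)c3cnn(C4CCC5(CC4)OCCO5)c3n2)cc1)Nc1cccnc1` gives 1 nM as its value
compound 3 `O=C(Nc1ccncc1)Nc1ccc(-c2nc(N3CC4CCC(C3)O4)c3cnn(C4CCC5(CC4)OCCO5)c3n2)cc1` gives 1 nM as its value

Of these three, compound 1 stands highest, and its gap to each of the other two lies beyond the scatter. Compound 4 `CNC(=O)Nc1ccc(-c2nc(N3CC4CCC(C3)O4)c3cnn([C@H]4CC[C@@H](O)CC4)c3n2)cc1` has not yet been measured. It departs from compound 1 at one place, with 4-hydroxycyclohexyl in place of isopropyl on an aromatic nitrogen. Among the compounds with values here, the only measured single-place step is no change at the digits printed from compound 2 to compound 3 (within the scatter) for pyridin-4-yl in place of pyridin-3-yl on an amide-type nitrogen. That step does not touch the aromatic nitrogen, so it offers no direct size for this change. Compound 2, at 1 nM, and compound 3, at 1 nM, also carry a ring-bearing group on that aromatic nitrogen. Both differ from compound 1 at the amide-type nitrogen as well, so their lower numbers cannot be credited to the aromatic nitrogen alone. They give only weak support for a small move toward a lower number in this assay, possibly one no larger than the scatter. The estimated step is a 1.7-fold lower number from compound 1 to compound 4 (0.22 log units; within the scatter) on this reasoning. For compound 4 the expected value is 3 nM, with an estimated range from 1 nM to 10 nM in this measurement.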

Compound 4, half-maximal inhibitory concentration: 20 nM
Compound 4: the middle estimate sits 6.7-fold (0.82 log units) below what was measured; the measured number lies above the stated range.
By their numbers in this assay, from the lowest: compounds 2 and 3 (each within the scatter of the next); then compound 1; then compound 4.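

In this assay, the change to 4-hydroxycyclohexyl in place of isopropyl on the aromatic nitrogen gives a 4.0-fold higher number from compound 1 to compound 4 (0.60 log units; beyond the scatter), the first single-place step read at this position. Within the data shown here, the earlier comparison of compound 2 with compound 3 concerned only the amide-type nitrogen, so this step is the first to show that the group on the aromatic nitrogen alone can shift the number beyond the scatter, here upward, and the low values of compound 2 and compound 3 therefore cannot be taken as a sign that a ring-bearing group there lowers the number. The change brings in a ring, a hydroxyl and two defined stereocentres at once, and nothing available accounts for the rise or assigns it to any one of these.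

The compounds shown leave open whether the higher number goes with the ring or with the hydroxyl, which a plain cyclohexyl or a 4-aminocyclohexyl on the same nitrogen would help to separate. They also leave open whether the step keeps its direction and size when a pyridin-3-yl or pyridin-4-yl stands on the amide-type nitrogen in place of the methyl of compound 1.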